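This account rests on a few compounds, and the source may have more. Where it says the series, first, only, none or still open, it means among the compounds named here.

Compound 1 `COc1cccc(/C=C/C(=O)c2ccc(OC)c3c2OC(C)(C)C=C3)c1` carries a 3-methoxyphenyl group on the double-bonded chain of its shared core. In a functional assay on HT-29 cells (Homo sapiens) for antiproliferative activity, read by MTT assay, with a stated time of 24 h (on this read-out lower numbers stand for stronger inhibition and higher numbers for weaker inhibition), compound 1 gives > 10000 nM, which is a limit of the assay rather than a measured number. Compound 2 `COc1ccc(C(=O)/C=C/c2ccc(N(c3ccccc3)c3ccccc3)cc2)c2c1C=CC(C)(C)O2` shares the same core and gives > 10000 nM, again a limit and not a number. Both values therefore sit at the limit of > 10000 nM in this assay, at which 2 of the 2 values shown sit, so neither compound can be ranked against the other on these data. Compound 3 `COc1ccc(/C=C/C(=O)c2ccc(OC)c3c2OC(C)(C)C=C3)cn1` is the compound still to be measured. It differs from compound 1 by 6-methoxypyridin-3-yl in place of 3-methoxyphenyl on a double-bonded chain carbon bound to a double-bonded chain carbon. Going by the values given here, no measured pair of compounds shows this change, so its effect is unknown, and the expectation is that the step that the limit leaves unreadable from compound 1 to compound 3 stays within the usual scatter. Compound 3 is thus expected to give about 15000 nM, with a range from 5000 nM to 50000 nM, most likely reported once more as a limit.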

Compound 3, half-maximal inhibitory concentration: > 10000 nM
Compound 3 ended at the assay's limit (the forecaster's own chance of this, stated with the estimate: 75%); the middle value lies beyond the limit too.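

No step can be read from compound 1 to compound 3, because both results are limits and not numbers: the limit of > 10000 nM in this assay, at which 3 of the 3 values shown sit.

The compounds shown leave open whether 6-methoxypyridin-3-yl in place of 3-methoxyphenyl changes the activity at all, and which change to the shared core would give a measurable number in this assay.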